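Fluoro to bromo on the phenoxy ring of compound 2

The compounds below may be only part of what the source reports. "The series", "measured", "known", "first", "only" and "open" are said of these compounds alone.

Compound 1, `Cc1nn(C)c(Oc2ccc(F)cc2)c1/C=N\OCc1c(Cl)c(-c2ccc(F)cc2)nn1C`: 7080 nM
Compound 2, `Cc1nn(C)c(Oc2ccc(F)cc2)c1/C=N\OCc1c(Cl)c(-c2ccc(Cl)cc2)nn1C`: 4430 nM

In a functional assay on SGC-7901 cells (Homo sapiens) for antiproliferative activity, read by MTT assay, with a stated time of 72 h (a higher number here means a weaker inhibitor, a lower number a stronger inhibitor), compound 1 gives 7080 nM and compound 2 gives 4430 nM. Within the data shown here, the single measured step, a 1.6-fold lower number from compound 1 to compound 2 (0.20 log units; within the scatter), lies within the scatter, so the two compounds cannot be told apart on these numbers. Compound 2 carries the lower of the two values, yet the gap to compound 1 is too small to call it the stronger inhibitor.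

Compound 3, `Cc1nn(C)c(Oc2ccc(Br)cc2)c1/C=N\OCc1c(Cl)c(-c2ccc(Cl)cc2)nn1C`, is the next variation. It differs from compound 2 in one place: bromo in place of fluoro on an aromatic carbon. Among the measured compounds shown here, the one step seen so far also exchanges a halogen on an aromatic carbon, though on the other six-membered ring of the shared core, and it produced no change beyond the scatter. On that basis the expected step in this assay from compound 2 to compound 3 is small, with no clear direction, and is estimated at a 1.2-fold lower number from compound 2 to compound 3 (0.07 log units; within the scatter). Compound 3 is therefore expected to give about 3800 nM, with a likely range from 1600 nM to 9000 nM.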

Compound 3, half-maximal inhibitory concentration: 5960 nM
Beside the measured number, compound 3's estimate is 1.6-fold (0.20 log units) below it; measured number inside the range.
By their numbers in this assay, from the lowest: compounds 2, 3 and 1 (each within the scatter of the next).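

In this assay, exchanging 4-fluorophenoxy for 4-bromophenoxy gives a 1.3-fold higher number from compound 2 to compound 3 (0.13 log units; within the scatter), so at this place on the phenoxy ring, fluoro and bromo cannot be told apart on these numbers. Among these compounds, this is the first look at a halogen exchange on this ring, and it agrees with the only earlier step, a 1.6-fold lower number from compound 1 to compound 2 (0.20 log units; within the scatter), where chloro replaced fluoro on the other six-membered ring and the change also stayed within the scatter. For these two single exchanges, then, the halogen's identity makes no readable difference in this assay, although no measurement here offers an explanation for that result.

Compound 1, compound 2 and compound 3 all keep a halogen at both of these ring positions, so they leave open whether a group of another kind, such as a methoxy, an amine or a carboxylic acid, would move the number beyond the scatter. They also leave open whether changing the shared core, rather than these outer halogens, would have a larger effect.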